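This account rests on a few compounds, and the source may have more. Where it says the series, first, only, none or still open, it means among the compounds named here.

Measured compounds:
- compound 1 `COc1ccc([C@@H]2CC(=O)c3c(O)cc(OCc4cn(Cc5ccc(C(F)(F)F)cc5)nn4)cc3O2)cc1O`: 17700 nM
- compound 2 `COc1ccc([C@@H]2CC(=O)c3c(O)cc(OCc4cn(Cc5cccc(Cl)c5)nn4)cc3O2)cc1O`: 18200 nM

In a functional assay on RAW264.7 cells (Mus musculus) for inhibition, read by Griess assay, with stated times of 2 h and 24 h (a lower number here means a stronger inhibitor, a higher number a weaker inhibitor), compound 1 gives 17700 nM, the smaller of the two numbers shown, yet a 1.0-fold higher number from compound 1 to compound 2 (0.01 log units; within the scatter), so the two compounds cannot be told apart. Compound 3 `COc1ccc([C@@H]2CC(=O)c3c(O)cc(OCc4cn(Cc5ccc(F)cc5)nn4)cc3O2)cc1O` is not yet measured. It differs from compound 1 in one place: fluoro in place of trifluoromethyl on an aromatic carbon. Within the data shown here, the only measured step, a 1.0-fold higher number from compound 1 to compound 2 (0.01 log units; within the scatter), changed a different ring substituent pattern on the same benzyl group and produced nothing beyond the scatter; it bears on the new change only loosely, but it is the sole guide available. Nothing in the shown data suggests that swapping groups on that outer ring moves the number, so no step beyond the scatter is expected in this assay. Compound 3 is therefore estimated at 18000 nM, with a range from 8000 nM to 40000 nM, meaning an expected step of a 1.0-fold higher number from compound 1 to compound 3 (0.01 log units; within the scatter).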

Compound 3, half-maximal inhibitory concentration: 15100 nM
For compound 3 the middle estimate is 1.2-fold (0.08 log units) above the measured one; measured number inside the range.
By their numbers in this assay, from the lowest: compounds 3, 1 and 2 (each within the scatter of the next).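

In this assay the swap of trifluoromethyl, with 4 heavy atoms, for fluoro, with 1 heavy atom, on this aromatic carbon gives a 1.2-fold lower number from compound 1 to compound 3 (0.07 log units; within the scatter) and so shows that this much smaller group leaves the number within the scatter. Set against the chlorine-bearing benzyl group, the 4-fluorobenzyl group gives a 1.2-fold lower number from compound 2 to compound 3 (0.08 log units; within the scatter) and so adds a third outer ring that cannot be told apart from the others. No measurement here offers an explanation for this flat result.

On these data alone, what an amine or a carboxylic acid on this outer ring would do remains open. Also open is whether a change to the shared core would move the number, since all of these compounds are alike there.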